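The source may hold more compounds than are shown below. What is called first, only, known or untested is meant among the compounds shown, and "the series" means these compounds.

Measured so far:
compound 1, `CCOC(=O)N1CCC(=NNC(=O)c2ccc(C(F)(F)F)cc2)CC1`: 23500 nM
compound 2, `CCOC(=O)N1CCC(=NNC(=O)c2ccc([N+](=O)[O-])cc2)CC1`: 10900 nM
compound 3, `O=C(NN=C1CC(c2ccccc2)NC(c2ccccc2)C1)c1ccc(C(F)(F)F)cc1`: 153000 nM

In a functional assay, read by spectrophotometry (a lower number here means a stronger inhibitor, a higher number a weaker inhibitor), compound 1 gives 23500 nM. Compound 2 gives 10900 nM in this assay. Compound 3 gives 153000 nM in this assay, the highest of the three numbers.

From compound 1 to compound 2 the change is nitro in place of trifluoromethyl on an aromatic carbon, and it made a 2.2-fold lower number from compound 1 to compound 2 (0.33 log units; beyond the scatter). Compound 4, `O=C(NN=C1CC(c2ccccc2)NC(c2ccccc2)C1)c1ccc([N+](=O)[O-])cc1`, carries the same change on the core of compound 3: nitro in place of trifluoromethyl on an aromatic carbon. The difference between the two cores is not broken down here.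

Among the measured compounds shown here, compound 4 is expected to sit a similar distance from compound 3 as compound 2 sits from compound 1, that is a 2.2-fold lower number from compound 3 to compound 4 (0.34 log units; beyond the scatter), resting on a 2.2-fold lower number from compound 1 to compound 2 (0.33 log units; beyond the scatter) as the only measured instance of this change. The estimate for compound 4 is 70000 nM, expected to fall between 25000 nM and 200000 nM.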

Compound 4, half-maximal inhibitory concentration: 170000 nM
Compound 4: the middle estimate sits 2.4-fold (0.39 log units) below what was measured, and the stated range covers the measured number.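

In this assay nitro in place of trifluoromethyl on an aromatic carbon gives a 1.1-fold higher number from compound 3 to compound 4 (0.05 log units; within the scatter) and thus no readable change on the core of compound 3. Set beside the earlier step, the two cores cannot be told apart: the same change on two cores in this assay, a 2.2-fold lower number (0.33 log units; beyond the scatter) from compound 1 to compound 2 and a 1.1-fold higher number (0.05 log units; within the scatter) from compound 3 to compound 4, 2.4-fold (0.38 log units) apart, within the scatter of two such steps. This gives no sign that the change behaves differently on the two cores, but two instances, one of them within the scatter, do not show that it carries over reliably.

On these data alone, whether other groups on that aromatic carbon, such as an amine or a carboxylic acid, would move the number on either core remains open. Which part of the difference between the two cores matters also remains open.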